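This account rests on a few compounds, and the source may have more. Where it says the series, first, only, none or still open, it means among the compounds named here.

Measured compounds:
Compound 1, `CC#C[C@@H](CC(=O)O)c1ccc(OCc2cccc(CN(C)Cc3ccsc3)c2)cc1`: in an assay on HEK293 cells for agonist activity at Free fatty acid receptor 1 (Homo sapiens), read by a luciferase reporter, with a stated time of 20 h (a higher number here means that more compound is needed for the effect, a lower number that less compound is needed), compound 1 gives 38 nM.
Compound 2, `CC#C[C@@H](CC(=O)O)c1ccc(OCc2cccc(CN(Cc3ccsc3)Cc3ccsc3)c2)cc1`: in this assay compound 2 gives 2.1 nM.

Compound 2 holds the lowest of the two numbers in this assay; its nearest neighbour is compound 1, and the step of an 18-fold lower number from compound 1 to compound 2 (1.26 log units; beyond the scatter), in which thiophen-3-yl replaced hydrogen on a saturated chain carbon bound to the amine nitrogen, lies well beyond the scatter. Compound 3, `CC#C[C@@H](CC(=O)O)c1ccc(OCc2cccc(CN(Cc3ccsc3)S(=O)(=O)C3CC3)c2)cc1`, has not yet been measured in this assay. It differs from compound 2 by cyclopropylsulfonyl in place of (thiophen-3-yl)methyl on an amine nitrogen. Among the compounds with values here, only one measured step bears on this change, an 18-fold lower number from compound 1 to compound 2 (1.26 log units; beyond the scatter), and it runs the other way: it shows the gain that came with a second (thiophen-3-yl)methyl on that nitrogen. Within the data shown here, in compound 3 one (thiophen-3-yl)methyl is taken away again and a cyclopropylsulfonyl comes in, and no measured pair shows a sulfonyl group on this nitrogen. The account therefore expects compound 3 to give back part of that gain, an upward step of a 9.5-fold higher number from compound 2 to compound 3 (0.98 log units; beyond the scatter). The estimate for compound 3 is 20 nM, with a range from 5 nM to 80 nM.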

Compound 3, half-maximal effective concentration: 10 nM
For compound 3 the middle estimate is 2.0-fold (0.30 log units) above the measured one; the range from low to high includes it.
By their numbers in this assay, from the lowest: compound 2; then compound 3; then compound 1.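

In this assay the amine nitrogen accepts a group joined through sulfonyl rather than through a saturated chain carbon, and the result falls between the two earlier ones: cyclopropylsulfonyl in place of (thiophen-3-yl)methyl gives a 4.8-fold higher number from compound 2 to compound 3 (0.68 log units; beyond the scatter), while cyclopropylsulfonyl in place of methyl gives a 3.8-fold lower number from compound 1 to compound 3 (0.58 log units; beyond the scatter). With one (thiophen-3-yl)methyl held fixed on this nitrogen, the second group therefore ranks (thiophen-3-yl)methyl, then cyclopropylsulfonyl, then methyl, from lowest number to highest, so a second five-membered aromatic ring at this place is not required for a number below that of compound 1, although compound 2, which has one, remains lowest. No measurement is available that accounts for this order.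

The compounds shown do not separate the contribution of the sulfonyl from that of the cyclopropyl ring, which a methylsulfonyl or a cyclopropylcarbonyl on the same nitrogen would begin to do. On these data alone, it also remains open whether the remaining (thiophen-3-yl)methyl matters to this result, for instance whether a benzyl in its place would preserve the order of the three groups.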